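Replacing dimethylamino with methyl on the pyridine ring

This account rests on a few compounds, and the source may have more. Where it says the series, first, only, none or still open, it means among the compounds named here.

Measured compounds:
Compound 1 `CC[C@H](C)[C@@H]1C(=O)N[C@H](C2Cc3ccccc3C2)C(=O)N1[C@@H](C(=O)N1CCOCC1)c1ccc(C)nc1`: 1450 ng.h/mL
Compound 2 `COc1ccc([C@H](C(=O)N(C)C)N2C(=O)[C@@H](C3Cc4ccccc4C3)NC(=O)[C@H]2CC(C)C)cn1`: 2230 ng.h/mL
Compound 3 `CC(C)C[C@@H]1C(=O)N[C@H](C2Cc3ccccc3C2)C(=O)N1[C@@H](C(=O)N(C)C)c1ccc(N(C)C)nc1`: 135 ng.h/mL

In an ADME assay on the whole organism (plasma) for pharmacokinetics, with Rattus norvegicus as the target, at a dose of 5 mg/kg by the oral route (on this read-out lower numbers stand for lower exposure and higher numbers for higher exposure at the dose given), compound 3 gives the lowest number of the three. The next compound, compound 4 `Cc1ccc([C@H](C(=O)N(C)C)N2C(=O)[C@@H](C3Cc4ccccc4C3)NC(=O)[C@H]2CC(C)C)cn1`, differs from compound 3 in one place: methyl in place of dimethylamino on an aromatic carbon. The closest measured step is a 17-fold lower number from compound 2 to compound 3 (1.22 log units; beyond the scatter), a large drop when dimethylamino entered for methoxy. The change here removes that dimethylamino group again, so a large rise back in this assay is expected. Compound 1 carries the same methyl group on the same ring, with other differences elsewhere, and gives 1450 ng.h/mL. Compound 4 is therefore expected to rise by about a 12-fold higher number from compound 3 to compound 4 (1.07 log units; beyond the scatter), to an estimated 1600 ng.h/mL, between 600 ng.h/mL and 4000 ng.h/mL.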

Compound 4, area under the concentration-time curve: 2680 ng.h/mL
The estimate for compound 4 lay 1.7-fold (0.22 log units) below the measured number; the range from low to high includes it.
By their numbers in this assay, from the lowest: compound 3; then compounds 1, 2 and 4 (each within the scatter of the next).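

In this assay the swap gives a 20-fold higher number from compound 3 to compound 4 (1.30 log units; beyond the scatter), so on this aromatic carbon next to the ring nitrogen, methyl undoes the drop seen with dimethylamino, just as methoxy stands high. Methyl and methoxy cannot be told apart here, with a 1.2-fold higher number from compound 2 to compound 4 (0.08 log units; within the scatter), which leaves dimethylamino as the only one of the three groups in this series that goes with low exposure. Nothing in the data gives a reason for this. Still open, on these data alone, is whether a plain amino group, a methylamino group or a longer chain such as ethyl would go with high or low exposure at this place.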